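The source may hold more compounds than are shown below. What is called first, only, known or untested is meant among the compounds shown, and "the series" means these compounds.

For the measured compounds named here, compound 2, `O=C(N/N=C/c1ccc(Cl)cc1)c1cccnc1Nc1cccc(C(F)(F)F)c1`, is one of two compounds so far tested in a functional assay on the whole organism (strain Wistar) for inhibition, with Rattus norvegicus as the target, read by paw edema, with a stated time of 3 h, at a dose of 10 mg/kg by the intraperitoneal route; on this read-out lower numbers stand for less inhibition and higher numbers for more inhibition at the one dose given (going by the name of the read-out). In this assay compound 2 gives 48.5%. Going by the values given here, its only companion is compound 1, `O=C(N/N=C/c1ccc(F)cc1)c1cccnc1Nc1cccc(C(F)(F)F)c1`, which in this assay gives 41.3%; the two numbers lie within the usual scatter of one another, and the single step that links them, a chloro in place of a fluoro on an aromatic carbon, changed the read-out by a number 7.2 percentage points higher from compound 1 to compound 2 (within the scatter).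

Compound 3, `O=C(N/N=C/c1cccc(O)c1)c1cccnc1Nc1cccc(C(F)(F)F)c1`, has not yet been measured. It differs from compound 2 in one place: 3-hydroxyphenyl in place of 4-chlorophenyl on a carbon with a double bond to nitrogen. Among the compounds with values here, no measured step bears on this kind of exchange; the one step available swaps one halogen for another and was itself within the scatter. With nothing in the data pointing in either direction, a step of no size beyond the scatter is expected, and the estimated step in this assay is a number 4.5 percentage points lower from compound 2 to compound 3 (within the scatter). Compound 3 is therefore expected to give about 44% in this assay, with a range from 30% to 58%.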

Compound 3, a percentage reported as inhibition, in the whole organism at one dose (the size of the read-out at that dose, not a potency): 49%
Compound 3: middle estimate off by 5 percentage points, on the low side; low and high end bracket the measured number.
By their numbers in this assay, from the lowest: compounds 1, 2 and 3 (each within the scatter of the next).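

In this assay the exchange of 3-hydroxyphenyl in place of 4-chlorophenyl on a carbon with a double bond to nitrogen comes to a number 0.5 percentage points higher from compound 2 to compound 3 (within the scatter) and the exchange of 3-hydroxyphenyl in place of 4-fluorophenyl at that same place comes to a number 7.7 percentage points higher from compound 1 to compound 3 (within the scatter) in the same read-out. The earlier pair showed only one halogen exchanged for another, whereas these steps replace a halogen-bearing ring having no hydrogen-bond donor or acceptor with a hydroxy-bearing ring having one of each, and neither step lies beyond the scatter. Nothing given here offers a measured reason for this outcome.

The compounds shown leave open whether a ring carrying an amine or a carboxylic acid, or a saturated alkyl chain such as butyl in place of the ring, would also stay within the scatter at this place. They also leave open how the three compounds compare in potency, since each number is the size of the read-out at a single dose and the three numbers lie within the scatter of one another.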